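From phenyl to butyl on a shared core

This account rests on a few compounds, and the source may have more. Where it says the series, first, only, none or still open, it means among the compounds named here.

Measured in a functional assay for inhibition, with Rattus norvegicus as the target; a lower number here means a stronger inhibitor, a higher number a weaker inhibitor
Compound 1 (`COc1c(-c2ccccc2)c(-c2ccccc2)c(OC(C)=O)c2ccn(C)c12`) gives "not active" (no number reported)
Compound 2 (`COc1cc(-c2ccccc2)c(OC(C)=O)c2ccn(C)c12`) gives 3860 nM

Within the data shown here, compound 2 holds the only number so far, since compound 1 was reported without one. Compound 3 (`CCCCc1cc(OC)c2c(ccn2C)c1OC(C)=O`) has not yet been measured. It has butyl in place of phenyl on an aromatic carbon. Among the measured compounds shown here, no measured pair shows what this swap does, so no change beyond the usual scatter is expected in this assay, in either direction. The estimated change is small (a 1.1-fold lower number from compound 2 to compound 3 (0.04 log units; within the scatter)). Compound 3 is expected at 3500 nM (estimated range 900 nM to 14000 nM).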

Compound 3, half-maximal inhibitory concentration: 720 nM
Beside the measured number, compound 3's estimate is 4.9-fold (0.69 log units) above it, outside the stated range (below it).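

In this assay, among these compounds, this is the first measured sign that the group on this aromatic carbon, ortho to an acetoxy group, matters: butyl in place of phenyl gives a 5.4-fold lower number from compound 2 to compound 3 (0.73 log units; beyond the scatter). For this one pair, an aromatic ring at this place is not needed for activity, and a chain without a ring does better. Nothing measured here explains the change. Butyl is the only chain shown, so it remains open whether a shorter propyl chain or a longer hexyl chain would do better or worse. An amine at the end of the chain is equally untested among these compounds.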